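The source may hold more compounds than are shown below. What is called first, only, known or untested is meant among the compounds shown, and "the series" means these compounds.

The measured compounds: compound 1 `Cc1nc(N2CCCCC2)c2nnn(-c3ccc(C(C)C)cc3Br)c2n1` with 46 nM; compound 2 `CCC(CC)Nc1nc(C)nc2c1nnn2-c1c(C)cc(C)cc1C` with 5.7 nM; compound 3 `CCCC(C)Nc1nc(C)nc2c1nnn2-c1c(C)cc(C)cc1C` with 7.1 nM, all in an in vitro assay on 293-EBNA cells for binding affinity to corticotropin-releasing factor receptor 1 (Homo sapiens); on this read-out higher numbers stand for weaker inhibition and lower numbers for stronger inhibition.

Compound 1 stands highest of the three in this assay; compound 3 and compound 2 both lie beyond the scatter below it. Between compound 2 and compound 3, which carry a pentan-3-yl and a 1-methylbutyl group on the ring nitrogen, the step of a 1.2-fold higher number from compound 2 to compound 3 (0.10 log units; within the scatter) is within the scatter.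

Compound 4 `COCC(COC)Nc1nc(C)nc2c1nnn2-c1ccc(C(C)C)cc1Br` differs from compound 1 in one place: (2-methoxy-1-(methoxymethyl)ethyl)amino in place of piperidin-1-yl on an aromatic carbon. For the measured compounds named here, no measured step covers this exchange directly. Compound 2 and compound 3 carry an alkylamino group at this place and give lower numbers than compound 1, but they also carry a different aryl group on the triazole nitrogen, so their comparison with compound 1 is not a single-point step. By this indirect comparison compound 4 is expected to give a lower number than compound 1, a step of a 3.8-fold lower number from compound 1 to compound 4 (0.58 log units; beyond the scatter). The estimate for compound 4 is 12 nM, with a range from 4 nM to 40 nM.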

Compound 4, inhibition constant: 10.3 nM
Compound 4: middle estimate off by 1.2-fold (0.07 log units), on the high side; measured number inside the range.
By their numbers in this assay, from the lowest: compounds 2, 3 and 4 (each within the scatter of the next); then compound 1.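

For the compounds shown here, with the rest of the structure held constant, compound 1 and compound 4 give the first single-place reading of this aromatic carbon in this assay: the exchange of piperidin-1-yl for (2-methoxy-1-(methoxymethyl)ethyl)amino gives a 4.5-fold lower number from compound 1 to compound 4 (0.65 log units; beyond the scatter). The larger open-chain group is accepted here, yet the exchange removes a ring and adds a hydrogen-bond donor and two oxygen atoms all at once, so the step belongs to the whole change and to no single feature of it. Nothing available explains the shift.

The compounds shown leave open whether the amine hydrogen or the two methoxy groups account for the step. Pentan-3-ylamino or morpholin-4-yl at this place on the core of compound 1 would separate these features.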